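Methoxy on the Pendant Phenyl of Compound 1

A few compounds are considered here, and "the series" means these few. Any claim that something is new, unique, unknown or untested is made for them only; others in the source may bear on it.

Compound 1 `COc1cc(/C=C/C(=O)c2cccc(-n3cc(-c4ccccc4)[nH]c3=O)c2)ccc1O` is the stronger of the two measured compounds in a functional assay on HCC 2998 cells (Homo sapiens) for inhibition (on this read-out lower numbers stand for stronger inhibition of growth and higher numbers for weaker inhibition of growth), giving 1510 nM. Compound 2 `O=C(/C=C/c1cccc(O)c1)c1cccc(-n2cc(-c3ccccc3)[nH]c2=O)c1` gives 4090 nM in this assay, and the step of a 2.7-fold higher number from compound 1 to compound 2 (0.43 log units; beyond the scatter) is the only measured one available. Compound 3 `COc1ccc(-c2cn(-c3cccc(C(=O)/C=C/c4ccc(O)c(OC)c4)c3)c(=O)[nH]2)cc1` differs from compound 1 by methoxy in place of hydrogen on an aromatic carbon, the place being para to a large group on the six-membered aromatic ring of carbon only; cut one bond further out it reads phenyl to 4-methoxyphenyl. Going by the values given here, the measured step from compound 1 to compound 2 concerns a different ring on a double-bonded chain carbon, so no measured step bears directly on this change. With no guidance from the data, the number for compound 3 in this assay is expected to stay close to that of compound 1, with a step of a 1.0-fold lower number from compound 1 to compound 3 (0.00 log units; within the scatter) estimated. The estimate for compound 3 is therefore 1500 nM, with a range from 600 nM to 3800 nM.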

Compound 3, concentration for 50% growth inhibition: 2320 nM
Compound 3: middle estimate off by 1.5-fold (0.19 log units), on the low side; the measured number falls inside the stated range.
By their numbers in this assay, from the lowest: compounds 1, 3 and 2 (each within the scatter of the next, the first and the last beyond it).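

In this assay, replacing phenyl with 4-methoxyphenyl gives a 1.5-fold higher number from compound 1 to compound 3 (0.19 log units; within the scatter), so at this place, para to a large group, methoxy leaves a number that cannot be told apart from that of compound 1. Going by these compounds alone, this is the first measured change on this ring, whereas the only earlier step, a 2.7-fold higher number from compound 1 to compound 2 (0.43 log units; beyond the scatter), lay beyond the scatter and concerned the ring on the double-bonded chain carbon. No evidence is available to explain this result.

A single methoxy at one place leaves open how the read-out would respond to an amine, a carboxylic acid or a longer alkoxy chain there. The compounds shown also leave open whether 4-methoxyphenyl would give a similarly small step when paired with the 3-hydroxyphenyl of compound 2.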